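A few compounds are considered here, and "the series" means these few. Any claim that something is new, unique, unknown or untested is made for them only; others in the source may bear on it.

Compound 1 `O=C1O/C(=C\Cn2cc(Cc3ccccc3)nn2)C(OCc2ccccc2)=C1OCc1ccccc1` carries a benzyl group on its triazole ring. In a functional assay on HCT-116 cells (Homo sapiens) for antiproliferative activity, read by MTT assay, with a stated time of 24 h (on this read-out higher numbers stand for weaker inhibition and lower numbers for stronger inhibition), compound 1 gives 83100 nM. Compound 2 `CC(C)(C)c1ccc(-c2cn(C/C=C3\OC(=O)C(OCc4ccccc4)=C3OCc3ccccc3)nn2)cc1` differs from it by the change (benzyl in place of 4-(tert-butyl)phenyl on an aromatic carbon). In this assay compound 2 reaches only a limit of the assay, > 100000 nM. Going by the values given here, that step, an at least 1.2-fold lower number from compound 2 to compound 1 (0.08 log units; that floor lies within the scatter), is the one measured example of this change. Compound 3 `CC(C)(C)c1ccc(-c2cn(CCC3(O)NC(=O)C(OCc4ccccc4)=C3OCc3ccccc3)nn2)cc1` has a different core; how the two cores differ is not broken down here. In this assay compound 3 likewise gives only a limit, > 100000 nM. Compound 4 `O=C1NC(O)(CCn2cc(Cc3ccccc3)nn2)C(OCc2ccccc2)=C1OCc1ccccc1` has not been measured in this assay and differs from compound 3 by benzyl in place of 4-(tert-butyl)phenyl on an aromatic carbon, the same change. The expected step is an at least 1.0-fold lower number from compound 3 to compound 4 (0.02 log units; that floor lies within the scatter), resting on the earlier step of an at least 1.2-fold lower number from compound 2 to compound 1 (0.08 log units; that floor lies within the scatter) and on (the limit of > 100000 nM in this assay, at which 2 of the 3 values shown sit). For compound 4 the estimate is 95000 nM, between 45000 nM and 200000 nM.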

Compound 4, half-maximal inhibitory concentration: 51200 nM
For compound 4 the middle estimate is 1.9-fold (0.27 log units) above the measured one; measured number inside the range.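

In this assay, benzyl in place of 4-(tert-butyl)phenyl on the core of compound 3 gives an at least 1.9-fold lower number from compound 3 to compound 4 (0.29 log units; that floor lies within the scatter). Set beside the earlier step, this shows the change once more without a rise in the number, though neither floor goes beyond the scatter: the same change on two cores in this assay, an at least 1.2-fold lower number (0.08 log units; that floor lies within the scatter) from compound 2 to compound 1 and an at least 1.9-fold lower number (0.29 log units; that floor lies within the scatter) from compound 3 to compound 4; the limit leaves it open whether they differ. It does not show that the change carries over from one core to the other by the same amount, since compound 2 and compound 3 each start from a limit and neither step has a true size: the limit of > 100000 nM in this assay, at which 2 of the 4 values shown sit.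

The compounds shown leave open how an amine or a carboxylic acid in place of benzyl would read in this assay. They also leave open what a longer chain carrying the phenyl ring would do at this place on either core.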